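The compounds below may be only part of what the source reports. "The series", "measured", "known", "first", "only" and "open" are said of these compounds alone.

Working notes on the series. Going by the values given here, compound 1, `CCOc1ccc(C(=O)/C=C/c2ccc(Br)cc2)cc1`, gives 210 nM in an assay on isolated protein for inhibition of Amine oxidase [flavin-containing] B (Homo sapiens) (on this read-out lower numbers stand for stronger inhibition and higher numbers for weaker inhibition), and is the one compound here with a measured number. Compound 2, `O=C(/C=C/c1ccc(F)cc1)c1ccc(-n2ccnc2)cc1`, in this assay gives only > 10000 nM, which is a limit of the assay and not a number. Where compound 2 stands on the numbers shown is therefore only this: it sits at the limit of > 10000 nM in this assay, at which 1 of the 2 values shown sits. Compound 3, `O=C(/C=C/c1ccc(Br)cc1)c1ccc(-n2ccnc2)cc1`, differs from compound 2 by bromo in place of fluoro on an aromatic carbon. Among the compounds with values here, no measured step between two compounds shows what this change does on the shared core of compound 2; compound 1 carries bromo on its ring, but its remaining difference from compound 2 is not a single change and is not read as a step. The step of an at least 1.2-fold lower number from compound 2 to compound 3 (0.09 log units; that floor lies within the scatter) is expected to be modest, toward stronger inhibition if anything, given that compound 2 rests at a limit. The estimate for compound 3 in this assay is 8000 nM, between 2000 nM and 30000 nM, with a real chance that the assay again reports only a limit.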

Compound 3, half-maximal inhibitory concentration: 320 nM
For compound 3 the middle estimate is 25-fold (1.40 log units) above the measured one; the whole stated range lies above it.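

In this assay, the change from 4-fluorophenyl to 4-bromophenyl on the shared core gives the first single-place step read at this position, and it is large: an at least 31-fold lower number from compound 2 to compound 3 (1.49 log units; beyond the scatter). Compound 2 stands only at a limit of the assay, which is not a number, so the full size of this step cannot be given: the limit of > 10000 nM in this assay, at which 1 of the 3 values shown sits. With 4-bromophenyl held fixed, 1H-imidazol-1-yl in place of ethoxy on an aromatic carbon gives a 1.5-fold higher number from compound 1 to compound 3 (0.18 log units; within the scatter), which lies within the scatter, so the 1H-imidazol-1-yl group on this pair goes together with inhibition on a par with the ethoxy group when bromo is present.

Going by these compounds, whether a chloro or a methyl group at this place would keep the inhibition of the bromo compounds, or whether this read-out responds to bromo alone, stays open. On these data alone, it is also open whether 4-fluorophenyl paired with the ethoxy group would fall away as it does with the 1H-imidazol-1-yl group, since the fluoro to bromo step is read on one core only.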